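Lengthening the chain on compound 3

The source may hold more compounds than are shown below. What is called first, only, known or untested is meant among the compounds shown, and "the series" means these compounds.

Measured in a functional assay on MDA-MB-231 cells (Homo sapiens) for inhibition, read by MTT assay, with a stated time of 24 h; a lower number here means a stronger inhibitor, a higher number a weaker inhibitor: compound 1 `Fc1ccc(-c2cc(/C=N/c3ccccc3)on2)cc1` gives 41200 nM. Compound 2 `Cc1ccc(-c2cc(/C=N/c3ccccc3)on2)cc1` gives 29400 nM. Compound 3 `CCc1cc2ccccc2nc1-c1cc(-c2ccccc2)no1` gives only a limit of the assay, > 100000 nM.

Going by the values given here, the one measured step between compounds differing in a single place, a 1.4-fold lower number from compound 1 to compound 2 (0.15 log units; within the scatter), concerns a substituent on an aromatic carbon and has no counterpart in the change considered here. Compound 3 stands at the limit of > 100000 nM in this assay, at which 1 of the 3 values shown sits. Compound 4 `CCCCCc1cc2ccccc2nc1-c1cc(-c2ccccc2)no1` differs from it by propyl in place of hydrogen on a saturated chain carbon, two bonds along the chain from an aromatic carbon. Among the compounds with values here, no measured step bears on this change, so no step beyond the scatter is expected. The expected step is a number no higher from compound 3 to compound 4 (the limit leaves the size open). Compound 4 is therefore estimated at 100000 nM, with a range from 40000 nM to 300000 nM, and a limit rather than a number is again likely.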

Compound 4, half-maximal inhibitory concentration: > 100000 nM
Compound 4: no number, only a limit; the forecaster's own chance of this, stated with the estimate: 65%; the middle value lies on the limit itself.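

Compound 3 and compound 4 both sit at a limit in this assay and not at a number, so no step can be read between them: the limit of > 100000 nM in this assay, at which 2 of the 4 values shown sit. The compounds shown leave open whether propyl in place of hydrogen on this chain changes the inhibition at all.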